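This account rests on a few compounds, and the source may have more. Where it says the series, first, only, none or still open, it means among the compounds named here.

Compound 1, `Nc1nc(NCCNc2ncc(-c3ncc[nH]3)c(-c3ccccc3Cl)n2)ccc1[N+](=O)[O-]`, in an ADME assay on microsomes from liver (Rattus norvegicus) for metabolic stability (a higher number here means that the compound lasts longer, a lower number that the compound disappears faster), gives > 0.5 h, which is a limit of the assay rather than a number.
Compound 2, `Nc1nc(NCCNc2ncc(-c3ncc[nH]3)c(-c3ccccc3Br)n2)ccc1[N+](=O)[O-]`, in this assay gives > 0.5 h, again a limit of the assay.
Compound 3, `Nc1nc(NCCNc2ncc(-c3ncc[nH]3)c(-c3ccc(F)cc3Cl)n2)ccc1[N+](=O)[O-]`, in this assay gives > 0.5 h, also a limit of the assay.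

The change from compound 1 to compound 2 is bromo in place of chloro on an aromatic carbon. Its size in this assay is a step that the two limits leave unreadable from compound 1 to compound 2, and this is because of the limit of > 0.5 h in this assay, at which 3 of the 3 values shown sit. Compound 3 and compound 1 differ in their cores by fluoro in place of hydrogen on an aromatic carbon, and that step reads a step that the two limits leave unreadable from compound 1 to compound 3. Between compound 2 and compound 3 the step is a step that the two limits leave unreadable from compound 2 to compound 3.

The unmeasured compound 4, `Nc1nc(NCCNc2ncc(-c3ncc[nH]3)c(-c3ccc(F)cc3Br)n2)ccc1[N+](=O)[O-]`, differs from compound 3 by bromo in place of chloro on an aromatic carbon. For the measured compounds named here, this is the same kind of change as the one from compound 1 to compound 2, though not the same: in compound 4 the place is also meta to a fluoro group, while in compound 2 it is only ortho to a large group.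

In this assay the step from compound 3 to compound 4 is expected to be a step that the limit leaves unreadable from compound 3 to compound 4. That expectation rests on compound 1 and compound 2, where the same kind of change gave a step that the two limits leave unreadable from compound 1 to compound 2. It also rests on compound 3 reaching > 0.5 h. Compound 4 is therefore expected to give about 1 h, somewhere between 0.5 h and 3 h, and most likely to come back as a limit once more.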

Compound 4, half-life: > 0.5 h
Compound 4: no number, only a limit; the forecaster's own chance of this, stated with the estimate: 80%; the middle value is on the limit's open side.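

Compound 4 ends at a limit of the assay, as do compound 1, compound 2 and compound 3, so no step among these four compounds can be read in this assay: the limit of > 0.5 h in this assay, at which 4 of the 4 values shown sit.

The compounds shown leave open how long each one actually lasts, and so whether bromo in place of chloro or fluoro in place of hydrogen alters the half-life at all.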